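Adding a Second Chloro to the Aryl Head

This account rests on a few compounds, and the source may have more. Where it says the series, first, only, none or still open, it means among the compounds named here.

Compound 1 `COc1cc2c(Oc3ccc(NC(=O)c4nn(-c5cccc(F)c5)c(=O)cc4C)cc3F)ccnc2cc1OCCCN1CCCCC1` gives 1500 nM in a functional assay on U-87MG ATCC cells (Homo sapiens) for inhibition, read by MTT assay, with a stated time of 72 h; on this read-out higher numbers stand for weaker inhibition and lower numbers for stronger inhibition.
Compound 2 `COc1cc2c(Oc3ccc(NC(=O)c4nn(-c5ccc(Cl)cc5)c(=O)cc4C)cc3F)ccnc2cc1OCCCN1CCCCC1` gives 1400 nM in this assay.

Compound 2 holds the lower of the two numbers shown, but the step of a 1.1-fold lower number from compound 1 to compound 2 (0.03 log units; within the scatter) places it within the scatter of compound 1, so the two are not separated. Compound 3 `COc1cc2c(Oc3ccc(NC(=O)c4nn(-c5ccc(Cl)cc5Cl)c(=O)cc4C)cc3F)ccnc2cc1OCCCN1CCCCC1` differs from compound 2 by chloro in place of hydrogen on an aromatic carbon. Among the measured compounds shown here, only one measured step bears on this ring, and it was within the scatter; no measured step adds a group to it. Compound 3 is therefore expected to give no step beyond the scatter, no change at the digits printed from compound 2 to compound 3 (within the scatter). Compound 3 is estimated at 1400 nM, between 700 nM and 2800 nM.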

Compound 3, half-maximal inhibitory concentration: 1800 nM
For compound 3 the middle estimate is 1.3-fold (0.11 log units) below the measured one; the measured number falls inside the stated range.
By their numbers in this assay, from the lowest: compounds 2, 1 and 3 (each within the scatter of the next).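

In this assay, among the compounds shown here, the first added group on this aryl ring, a chloro ortho to a large group, gives a 1.3-fold higher number from compound 2 to compound 3 (0.11 log units; within the scatter) and so does not separate the two compounds. The comparison with the fluoro-bearing ring, a 1.2-fold higher number from compound 1 to compound 3 (0.08 log units; within the scatter), likewise shows no separation, so all three aryl heads remain unresolved in this assay. No evidence bears on this result.

As far as these compounds go, whether an amine or a carboxylic acid at this ortho position would shift the number beyond the scatter remains open, as does the effect of a methoxy group there.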